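The source may report more compounds than this note shows. Statements on the series, on what has been measured and on what is new or still open speak of the compounds shown alone.

Working notes on the shared core, read in a physicochemical assay for solubility, at pH 7; on this read-out lower numbers stand for lower solubility and higher numbers for higher solubility. Compound 1 `CN1CCC(C(=O)N2Cc3c(NC(=O)C4CC4)n[nH]c3C2(C)C)CC1` reaches only a limit of the assay in this assay, > 225000 nM. Compound 2 `CC(C)(C)C(=O)N1Cc2c(NC(=O)C3CCNCC3)n[nH]c2C1(C)C` likewise stops at a limit in this assay, > 225000 nM. Going by the values given here, compound 3 `CC(C)(C)C(=O)N1Cc2c(NC(=O)c3ccc(F)cc3)n[nH]c2C1(C)C` is the one member read as a number in this assay, 235000 nM. Among the compounds with values here, the single step between measured neighbours, a step that the limit leaves unreadable from compound 2 to compound 3, cannot be sized because of the limit of > 225000 nM in this assay, at which 2 of the 3 values shown sit. Within the data shown here, compound 1 therefore stands at the limit together with compound 2, and the only numerical reading, from compound 3, lies in the same region.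

Compound 4 `CN1CCC(C(=O)N2Cc3c(NC(=O)c4ccncc4)n[nH]c3C2(C)C)CC1` awaits measurement in this assay. Against compound 1 the difference is pyridin-4-yl in place of cyclopropyl on a carbonyl carbon. Among the measured compounds shown here, no measured step covers an exchange on this carbonyl carbon whose other neighbours are an amide-type nitrogen; the one measured step concerns another carbonyl and is itself unreadable. The exchanged group is small in both forms, and every value seen so far sits at or around the limit. Compound 4 is thus expected to remain in that region, so that an at least 1.1-fold lower number from compound 1 to compound 4 (0.05 log units; that floor lies within the scatter) is expected to stay within the scatter and a limit reading is again likely. Compound 4 is estimated at 200000 nM, with a range from 60000 nM to 400000 nM.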

Compound 4, solubility: > 225000 nM
Compound 4: only a limit was reported; the forecaster's own chance of this, stated with the estimate: 60%; at least 1.1-fold (0.05 log units) between middle value and limit.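

In this assay compound 4 gives > 225000 nM, which is a limit of the assay. No step can be read from compound 1 to compound 4, where pyridin-4-yl replaces cyclopropyl on a carbonyl carbon: the limit of > 225000 nM in this assay, at which 3 of the 4 values shown sit.

The compounds shown leave open the size of this exchange in this assay, and where compound 1, compound 2 and compound 4 would read as numbers.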